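Swapping the para substituent on the anilide of compound 2

This account rests on a few compounds, and the source may have more. Where it says the series, first, only, none or still open, it means among the compounds named here.

Going by the values given here, the two compounds measured so far share one core and differ only on that core. Compound 1 `COc1ccc(NS(=O)(=O)c2cc3cccc(Br)c3oc2=O)cc1` gives 15000 nM in a functional assay on DU-145 cells (Homo sapiens), with a stated time of 96 h; a higher number here means a weaker inhibitor of growth, a lower number a stronger inhibitor of growth. Compound 2 `CCOc1cccc2cc(S(=O)(=O)Nc3ccc(OC)cc3)c(=O)oc12`, with ethoxy in place of bromo on an aromatic carbon of the core, gives 57000 nM in this assay, and the step of a 3.8-fold higher number from compound 1 to compound 2 (0.58 log units; beyond the scatter) is the only measured one. Compound 2 therefore stands with the highest of the two numbers, and its nearest neighbour is compound 1.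

Compound 3 `CCOc1cccc2cc(S(=O)(=O)Nc3ccc(Br)cc3)c(=O)oc12` keeps the ethoxy of compound 2 and changes the other end of the molecule: bromo in place of methoxy on an aromatic carbon. Among the compounds with values here, no measured step touches this position; the single step from compound 1 to compound 2 concerns the core and is of modest size, so it offers no direct guidance here. With nothing pointing in either direction, the expected step of a 1.4-fold lower number from compound 2 to compound 3 (0.15 log units; within the scatter) is small. Compound 3 is thus estimated to give 40000 nM in this assay, within a range from 12000 nM to 130000 nM.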

Compound 3, concentration for 50% growth inhibition: 52000 nM
Beside the measured number, compound 3's estimate is 1.3-fold (0.11 log units) below it; the range from low to high includes it.
By their numbers in this assay, from the lowest: compound 1; then compounds 3 and 2 (each within the scatter of the next).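

Going by these compounds alone, the exchange read as 4-methoxyphenyl to 4-bromophenyl is the first measured change at this end of the molecule, and in this assay it gives a 1.1-fold lower number from compound 2 to compound 3 (0.04 log units; within the scatter), so compound 2 and compound 3 cannot be told apart. Within the data shown here, the only earlier step, a 3.8-fold higher number from compound 1 to compound 2 (0.58 log units; beyond the scatter), concerns the core and lies beyond the scatter, whereas this exchange of methoxy for bromo, on an aromatic carbon para to a large group, does not, at least with ethoxy on the core. Nothing available bears on why this exchange leaves the number within the scatter.

Going by these compounds, it remains open whether this position responds to a group of another kind, such as an amine or a carboxylic acid, in place of methoxy and bromo on that same aromatic carbon. On these data alone, it is also open whether the exchange of methoxy for bromo would read the same way on the core of compound 1, which carries bromo where compound 2 and compound 3 carry ethoxy.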